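The source may hold more compounds than are shown below. What is called first, only, known or untested is meant among the compounds shown, and "the series" means these compounds.

Compound 1 `CC(C)NC(=N)c1ccc2oc(-c3cccc(OCCCCCCOc4ccccc4)c3)cc2c1` and compound 2 `c1ccc(OCCCCCCOc2cccc(-c3cc4cc(C5=NCCN5)ccc4o3)c2)cc1` are built on one shared core and differ in a single group on an aromatic carbon. In an ADME assay on L6 cells (Rattus norvegicus) for cytotoxicity, read by resazurin assay, with a stated time of 70 h (a higher number here means a weaker inhibitor, a lower number a stronger inhibitor), compound 1 gives 7400 nM, while compound 2 gives 2500 nM. The change that separates them is a group of 5 heavy atoms (3 carbon, 2 nitrogen; one five-membered non-aromatic ring with 2 hetero atoms) in place of a group of 6 heavy atoms (4 carbon, 2 nitrogen; no ring), on an aromatic carbon and it made a step of a 3.0-fold lower number from compound 1 to compound 2 (0.47 log units; beyond the scatter).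

Compound 3 `CC(C)NC(=N)c1ccc2oc(-c3ccc(OCCCCOc4ccccc4)cc3)cc2c1` carries the same group as compound 1 but sits on a different core; how the two cores differ is not broken down here. In this assay compound 3 gives 6900 nM, a number close to that of compound 1 and apart from that of compound 2.

Compound 4 `c1ccc(OCCCCOc2ccc(-c3cc4cc(C5=NCCN5)ccc4o3)cc2)cc1` has not been measured. It stands to compound 3 as compound 2 stands to compound 1: the change from compound 3 to compound 4 is a group of 5 heavy atoms (3 carbon, 2 nitrogen; one five-membered non-aromatic ring with 2 hetero atoms) in place of a group of 6 heavy atoms (4 carbon, 2 nitrogen; no ring), on an aromatic carbon. The place of this change reads the same, word for word, as in the first pair, so it is the same change, occurring twice among these four compounds. Among the compounds with values here, only one measured example of it exists, so any forecast rests on a single step. The step from compound 3 to compound 4 is expected to be about a 2.9-fold lower number from compound 3 to compound 4 (0.46 log units; beyond the scatter) because the same change made a 3.0-fold lower number from compound 1 to compound 2 (0.47 log units; beyond the scatter) on the other core. Compound 4 is therefore estimated to give around 2400 nM in this assay, with a likely range from 1200 nM to 5000 nM.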

Compound 4, half-maximal inhibitory concentration: 2900 nM
For compound 4 the middle estimate is 1.2-fold (0.08 log units) below the measured one, within the range that was stated.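

On the second core, the same change gives a 2.4-fold lower number from compound 3 to compound 4 (0.38 log units; beyond the scatter) in this assay, so replacing the open-chain group with the five-membered non-aromatic ring lowers the number here as well. Set side by side, the two steps agree in direction and their sizes cannot be told apart: the same change on two cores in this assay, a 3.0-fold lower number (0.47 log units; beyond the scatter) from compound 1 to compound 2 and a 2.4-fold lower number (0.38 log units; beyond the scatter) from compound 3 to compound 4, 1.2-fold (0.09 log units) apart, within the scatter of two such steps This shows that, across these four compounds, the size of the step carried over from one core to the other, which gives some support to using one step to forecast the other; it does not show that the change would behave the same way on a third core, and it says nothing about why the number falls.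

The compounds shown leave open whether a different group on the same aromatic carbon, such as a simple amine, a carboxylic acid or a six-membered ring in place of the five-membered one, would lower the number to a similar extent. They also leave open whether the step would stay the same with a longer chain in the other part of the molecule, since the two cores shown cannot reveal how each feature of the core contributes on its own.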